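The source may report more compounds than this note shows. Statements on the series, on what has been measured and on what is new or still open speak of the compounds shown alone.

Measured compounds:
- compound 1 `CCC(C)(C)Cc1c[nH]c(CCc2ccc(-c3ccncc3)cc2)n1`, in a functional assay on HEK293 cells for agonist activity at Bombesin receptor subtype-3 (Homo sapiens), read by luminescence and calcium flux, with a stated time of 10 min (a higher number here means that more compound is needed for the effect, a lower number that less compound is needed), compound 1 gives 95 nM
- compound 2 `CCC(C)(C)Cc1c[nH]c(CCc2ccc(-c3cnccn3)cc2)n1`, in this assay compound 2 gives 100 nM

Going by the values given here, compound 2 carries the highest of the two numbers measured so far, but its nearest neighbour is compound 1, and the step of a 1.1-fold higher number from compound 1 to compound 2 (0.02 log units; within the scatter) sits within the scatter, so the two compounds are not separable on these data.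

The next compound in the series, compound 3 `CCC(C)(C)Cc1c[nH]c(CCc2ccc(-c3ccc(F)cn3)cc2)n1`, differs from compound 2 in one place: 5-fluoropyridin-2-yl in place of pyrazin-2-yl on an aromatic carbon. Among the compounds with values here, the only measured step that bears on this change is the exchange of one six-membered heteroaryl for another at the same position, a 1.1-fold higher number from compound 1 to compound 2 (0.02 log units; within the scatter), which left the number essentially unchanged. On that single precedent, no movement beyond the scatter is expected for the step to compound 3, though a single comparison gives a weak basis and the range is kept wide.

For compound 3 in this assay the expected step is no change at the digits printed from compound 2 to compound 3 (within the scatter), which means an estimated value of 100 nM with a range from 40 nM to 250 nM.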

Compound 3, half-maximal effective concentration: 97 nM
For compound 3 the middle estimate is 1.0-fold (0.01 log units) above the measured one; low and high end bracket the measured number.
By their numbers in this assay, from the lowest: compounds 1, 3 and 2 (each within the scatter of the next).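

In this assay, the exchange at this position, on an aromatic carbon para to a large group, now goes beyond swapping one unsubstituted heteroaryl for another: 5-fluoropyridin-2-yl brings a fluorine atom, 7 heavy atoms instead of 6, and 1 hydrogen-bond acceptor instead of 2, yet the result is (a 1.0-fold lower number from compound 2 to compound 3 (0.01 log units; within the scatter)). Measured against the pyridin-4-yl group of compound 1, the same group gives (a 1.0-fold higher number from compound 1 to compound 3 (0.01 log units; within the scatter)), so the three six-membered aromatic rings at this position cannot be separated in this read-out, whatever their number of ring nitrogens or the added fluorine. Nothing available accounts for this flat response, and no measurement beyond these numbers bears on it.

The compounds shown leave open whether the position responds at all to a group of a different kind, such as a plain phenyl, a morpholine, a carboxylic acid or a longer alkyl chain in place of the heteroaryl ring. They also leave the fluorine unresolved on its own, since a comparison with unsubstituted pyridin-2-yl would be needed to isolate it from the change of ring.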